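Acyl groups on the ring amine: compound 3 to compound 4

This account rests on a few compounds, and the source may have more. Where it says the series, first, only, none or still open, it means among the compounds named here.

In a physicochemical assay for lipophilicity, read by HPLC, measured as chromatographic lipophilicity, at pH 7.4 (on this read-out lower numbers stand for lower lipophilicity and higher numbers for higher lipophilicity), compound 3 `CN1CCC(C(=O)N2N=CCC2c2ccccc2)CC1` gives 1.1 and stands lowest of the three measured, with compound 1 `O=C(c1cccnc1)N1CCC(C(=O)N2N=CCC2c2ccccc2)CC1` at 2.6 and compound 2 `CCC(=O)N1CCC(C(=O)N2N=CCC2c2ccccc2)CC1` at 3.2 above it. Compound 4 `O=C(c1c[nH]nn1)N1CCC(C(=O)N2N=CCC2c2ccccc2)CC1` has (1H-1,2,3-triazol-4-yl)carbonyl in place of methyl on an amine nitrogen in a ring. Two measured steps put methyl at this same place, both large: (a number 1.50 log units lower from compound 1 to compound 3 (beyond the scatter)) and (a number 2.10 log units lower from compound 2 to compound 3 (beyond the scatter)). Read in reverse, both point upward. Within the data shown here, no measured compound carries the triazolyl ring, and compound 1 at 2.6 is the closer precedent since its group is also aromatic. A rise somewhat smaller than both steps is expected, estimated as a number 1.10 log units higher from compound 3 to compound 4 (beyond the scatter) in this assay terms. Compound 4 is expected at 2.2 (estimated range 1.6 to 2.8).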

Compound 4, distribution coefficient: 2
Compound 4: middle estimate off by 0.20 log units, on the high side; measured number inside the range.
By their numbers in this assay, from the lowest: compound 3; then compound 4; then compound 1; then compound 2.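

On the carbonyl carbon, in this assay, 1H-1,2,3-triazol-4-yl reads below both other acyl substituents (a number 0.60 log units lower from compound 1 to compound 4 (beyond the scatter); a number 1.20 log units lower from compound 2 to compound 4 (beyond the scatter)), so the aromatic groups at this position do not share one value. Even so, this acyl group stays above methyl on the amine nitrogen (a number 0.90 log units higher from compound 3 to compound 4 (beyond the scatter)), and all three acyl compounds now stand above compound 3. Nothing measured here accounts for the order among the acyl groups.

Open, as far as these compounds go, is where phenyl on the carbonyl carbon would fall in this assay. Also open, from the compounds shown here alone, is whether a methyl on a triazole ring nitrogen would shift the reading of compound 4.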